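This account rests on a few compounds, and the source may have more. Where it says the series, first, only, none or still open, it means among the compounds named here.

Of the compounds shown here, two have numbers so far in an ADME assay on the whole organism (strain Wistar Han) for metabolic stability, with Rattus norvegicus as the target, read by LC-MS, at a dose of 0.5 mg/kg by the intravenous route; on this read-out higher numbers stand for a longer-lived compound and lower numbers for a shorter-lived compound. Compound 1 `O=S(=O)(CCO)c1ccc(COC[C@@H]2C[C@@H]2C2CCN(c3ncc(Cl)cn3)CC2)c(F)c1` gives 0.9 h on this read-out, and compound 2 `CCOc1cnc(N2CCC([C@H]3C[C@H]3COCc3ccc(S(C)(=O)=O)c(F)c3)CC2)nc1` gives 0.8 h on the same scale. Compound 2 therefore stands within the scatter of compound 1, and the two values do not separate. Among the measured compounds shown here, these two compounds differ in more than one place, so no single-change step is available for calibration.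

Compound 3 `CCc1cnc(N2CCC([C@H]3C[C@H]3COCc3ccc(S(C)(=O)=O)c(F)c3)CC2)nc1` departs from compound 2 at one place, on an aromatic carbon of a six-membered aromatic ring with 2 nitrogen: ethyl in place of ethoxy on an aromatic carbon with ethyl in place of ethoxy. No measured swap of this kind exists in the data, so they give no firm direction. The expectation rests on compound 2 at 0.8 h and compound 1 at 0.9 h as the only anchors, and no change beyond the scatter is expected. The estimated move is a 1.1-fold higher number from compound 2 to compound 3 (0.05 log units; within the scatter) in this assay and should stay within the scatter. For compound 3 the estimated half-life is 0.9 h with an expected range from 0.45 h to 1.7 h as the working figure.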

Compound 3, half-life: 1 h
The estimate for compound 3 lay 1.1-fold (0.05 log units) below the measured number; the range from low to high includes it.
By their numbers in this assay, from the lowest: compounds 2, 1 and 3 (each within the scatter of the next).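

The pair gives the series its first single-change reading at this position, on an aromatic carbon of a six-membered aromatic ring with 2 nitrogen, two atoms from the ring nitrogen and para to a large group. In this assay, ethyl in place of ethoxy gives a 1.3-fold higher number from compound 2 to compound 3 (0.10 log units; within the scatter) and so leaves the two compounds unseparated, even though ethoxy carries an oxygen and a hydrogen-bond acceptor that ethyl lacks. Nothing at hand bears on why these two groups read alike.

Among the compounds shown here, this single swap covers only two small groups of closely related size, so it remains open whether an amine, a carboxylic acid or a longer chain such as butyl on the same aromatic carbon would also stay within the scatter on this half-life read-out. Compound 1 differs from compound 2 and compound 3 in more than one place, so the compounds shown cannot assign its value to any single group, and the hydroxyethyl on its sulfonyl remains without a one-change comparison.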